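Piperidine-nitrogen variation in a bis(4-fluorophenyl) thioether series

This account rests on a few compounds, and the source may have more. Where it says the series, first, only, none or still open, it means among the compounds named here.

Measured compounds:
compound 1 `Fc1ccc(CN2CCC(NCCSC(c3ccc(F)cc3)c3ccc(F)cc3)CC2)cc1`, 25.5 nM
compound 2 `Fc1ccc(C(SCCNC2CCN(Cc3ccc(C(F)(F)F)cc3)CC2)c2ccc(F)cc2)cc1`, 190 nM
compound 3 `OC(Cc1ccccc1)CN1CCC(NCCSC(c2ccc(F)cc2)c2ccc(F)cc2)CC1`, 31.4 nM

In an assay on membranes from striatum (strain Sprague-Dawley) for displacement of a labelled ligand from sodium-dependent dopamine transporter (Rattus norvegicus), read by scintillation counting, with a stated time of 120 min (on this read-out higher numbers stand for weaker inhibition and lower numbers for stronger inhibition), compound 3 stands second highest of the three numbers; compound 1 sits within the scatter of it a 1.2-fold higher number from compound 1 to compound 3 (0.09 log units; within the scatter), while compound 2 lies beyond it a 6.1-fold lower number from compound 2 to compound 3 (0.78 log units; beyond the scatter). Compound 4 `O=C(c1ccc(F)cc1)N1CCC(NCCSC(c2ccc(F)cc2)c2ccc(F)cc2)CC1` is not yet measured. Its change against compound 3: (4-fluorophenyl)carbonyl in place of 2-hydroxy-3-phenylpropyl on an amine nitrogen in a ring.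

Both measured steps touch the same ring nitrogen. A 4-fluorophenyl-bearing chain and a 1-hydroxy-2-phenylethyl chain give numbers within the scatter of each other, whereas a trifluoromethyl-bearing chain gives a modest rise. Going by the values given here, compound 4 carries a 4-fluorophenyl group, as compound 1 does, but joined through a carbonyl; no measured step covers that. A small-to-modest rise is therefore expected, a 2.5-fold higher number from compound 3 to compound 4 (0.41 log units; beyond the scatter). For compound 4 the estimate is 80 nM, within 25 nM to 300 nM.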

Compound 4, inhibition constant: 7.04 nM
Beside the measured number, compound 4's estimate is 11-fold (1.06 log units) above it, and the stated range ends above it.
By their numbers in this assay, from the lowest: compound 4; then compounds 1 and 3 (each within the scatter of the next); then compound 2.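

In this assay, going by these compounds alone, the ring amine nitrogen accepts a carbonyl link: (4-fluorophenyl)carbonyl in place of 4-fluorobenzyl gives a 3.6-fold lower number from compound 1 to compound 4 (0.56 log units; beyond the scatter) and is the first change at this nitrogen to fall beyond the scatter below compound 1. Against the other two chains it gives a 4.5-fold lower number from compound 3 to compound 4 (0.65 log units; beyond the scatter) and a 27-fold lower number from compound 2 to compound 4 (1.43 log units; beyond the scatter) and so makes compound 4 the strongest of the four. No measurement here accounts for this gain.

Still open, from the compounds shown here alone, is whether a sulfonyl link or a longer acyl chain on this nitrogen would hold the low number, and how a 4-(trifluoromethyl)phenyl group behaves on the carbonyl.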